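Replacing azido by amino on the cyclic phosphate core

This account rests on a few compounds, and the source may have more. Where it says the series, first, only, none or still open, it means among the compounds named here.

Measured so far:
compound 1 `CSc1nc2c(N)ncnc2n1[C@@H]1O[C@@H]2COP(=O)(O)O[C@H]2[C@H]1O` gives 804%
compound 2 `[N-]=[N+]=Nc1nc2c(N)ncnc2n1[C@@H]1O[C@@H]2COP(=O)(O)O[C@H]2[C@H]1O` gives 633%
compound 3 `CSc1nc2c(N)ncnc2n1[C@@H]1O[C@H](COP(=O)(O)O)[C@@H](O)[C@H]1O` gives 112%

These three compounds were tested in a functional assay on the whole organism for activation, with Mus musculus as the target, with stated times of 14 days and 2 h, at a dose of 30 mg/kg by the intravenous route; a higher number here means a stronger effect of the compound at the dose given, a lower number a weaker effect. Compound 2 stands second of the three numbers: compound 1 lies above it, and compound 3 lies far below it. Among the compounds with values here, the only single-place step among the measured compounds is a number 171 percentage points lower from compound 1 to compound 2 (beyond the scatter), so within the shared core an exchange of the group on that aromatic carbon moved the activity by a large amount.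

Compound 4 `Nc1ncnc2c1nc(N)n2[C@@H]1O[C@@H]2COP(=O)(O)O[C@H]2[C@H]1O` has not yet been measured. It differs from compound 2 in one place: amino in place of azido on an aromatic carbon. Within the data shown here, no measured step tells how an amino group behaves at that carbon, so the size and direction of the change can only be guessed. Among the measured compounds shown here, the one comparable step, the exchange of methylsulfanyl for azido, lowered the activity well beyond the scatter, which shows this position is sensitive to what sits on it. A second exchange at the same carbon could move the number either way, and the expected step of a number 133 percentage points lower from compound 2 to compound 4 (beyond the scatter) is taken as a moderate decrease with a wide range. Compound 4 is therefore expected to give about 500%, estimated between 200% and 800%.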

Compound 4, a percentage reported as activity, at one dose (the size of the read-out at that dose, not a potency): 607%
Beside the measured number, compound 4's estimate is 107 percentage points below it; the measured number falls inside the stated range.
By their numbers in this assay, from the lowest: compound 3; then compound 4; then compound 2; then compound 1.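

Exchanging azido for amino, which swaps three nitrogen atoms for one, gives a number 26 percentage points lower from compound 2 to compound 4 (beyond the scatter), so this second exchange on the aromatic carbon between two ring nitrogen atoms changes the read-out only modestly. The larger change comes from the exchange with methylsulfanyl, as a number 197 percentage points lower from compound 1 to compound 4 (beyond the scatter) shows, and this step points the same way as a number 171 percentage points lower from compound 1 to compound 2 (beyond the scatter): among these three compounds, both nitrogen groups give a lower number than methylsulfanyl, so the sensitivity of this carbon shows up mainly in that exchange. Nothing measured here accounts for this difference between the groups.

The compounds shown leave open whether ethylsulfanyl, with a longer chain on the sulfur, or a methylamino group at the same carbon would reach or pass the number given by methylsulfanyl. As far as these compounds go, it also remains open whether amino in place of methylsulfanyl would lower the number to a similar extent on the core of compound 3, which carries the same methylsulfanyl group but gives a much lower value of 112%.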